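From 2-(3-chlorophenyl)ethenyl to 2-(1H-pyrazol-1-yl)phenyl on the amide

A few compounds are considered here, and "the series" means these few. Any claim that something is new, unique, unknown or untested is made for them only; others in the source may bear on it.

Three compounds share one core and differ only in the aryl arm of the amide. In an assay on brain for displacement of a labelled ligand from D(3) dopamine receptor (Rattus norvegicus) (a lower number here means a stronger inhibitor, a higher number a weaker inhibitor), compound 1 `CCCN(CC[C@H]1CC[C@H](NC(=O)/C=C/c2ccc(F)cc2)CC1)[C@H]1CCc2nc(N)sc2C1` gives 1 nM. Compound 2 `CCCN(CC[C@H]1CC[C@H](NC(=O)/C=C/c2cccc(F)c2)CC1)[C@H]1CCc2nc(N)sc2C1` gives 9.9 nM in this assay, and compound 3 `CCCN(CC[C@H]1CC[C@H](NC(=O)/C=C/c2cccc(Cl)c2)CC1)[C@H]1CCc2nc(N)sc2C1` gives 1.2 nM. Compound 3 holds the second highest of the three numbers: its nearest neighbour is compound 1, with a 1.2-fold higher number from compound 1 to compound 3 (0.08 log units; within the scatter), and its furthest is compound 2, with an 8.3-fold lower number from compound 2 to compound 3 (0.92 log units; beyond the scatter). The move a 9.9-fold higher number from compound 1 to compound 2 (1.00 log units; beyond the scatter) is the other step beyond the scatter.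

Compound 4 `CCCN(CC[C@H]1CC[C@H](NC(=O)c2ccccc2-n2cccn2)CC1)[C@H]1CCc2nc(N)sc2C1` carries 2-(1H-pyrazol-1-yl)phenyl in place of 2-(3-chlorophenyl)ethenyl on a carbonyl carbon. Among the compounds with values here, none of the measured steps covers this exchange; they only swap or move a halogen on the phenyl while keeping the double bond, yet two of them are beyond the scatter, so this assay responds clearly to changes in this arm. Within the data shown here, with the double bond gone and a second aromatic ring entering, a step beyond the scatter in either direction is possible, and no measured pair points to a gain. A modest rise in the number is expected for compound 4, a 10-fold higher number from compound 3 to compound 4 (1.00 log units; beyond the scatter). The estimate for compound 4 in this assay is 12 nM, within a range of 2 nM to 70 nM.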

Compound 4, inhibition constant: 2 nM
Compound 4: the middle estimate sits 6.0-fold (0.78 log units) above what was measured; the range from low to high includes it.
By their numbers in this assay, from the lowest: compounds 1, 3 and 4 (each within the scatter of the next); then compound 2.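

Replacing 2-(3-chlorophenyl)ethenyl on the carbonyl carbon with 2-(1H-pyrazol-1-yl)phenyl gives, in this assay, a 1.7-fold higher number from compound 3 to compound 4 (0.22 log units; within the scatter), and the comparison with the 4-fluorophenyl analogue gives a 2.0-fold higher number from compound 1 to compound 4 (0.30 log units; within the scatter), so this position accepts an arm with no double bond outside aromatic rings and with a five-membered aromatic ring added, without a step beyond the scatter. Against the 3-fluorophenyl analogue, the same exchange gives a 5.0-fold lower number from compound 2 to compound 4 (0.69 log units; beyond the scatter), which leaves compound 2 as the only compound apart from the rest and the weakest of the four. No supporting measurement is available to explain how this arm fits with the halogen steps on the ethenyl series.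

The compounds shown do not separate the contribution of the pyrazole from that of the phenyl ring that carries it, a question that a 2-phenylphenyl or a plain phenyl arm on the carbonyl carbon would address. As far as these compounds go, it also remains open whether the new arm responds to a chloro or fluoro substituent on its phenyl ring as sharply as the ethenyl arm does.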